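Aryl variation on the ether chain carbon: compound 3 to 4

The source may report more compounds than this note shows. Statements on the series, on what has been measured and on what is new or still open speak of the compounds shown alone.

Measured in an assay on lysate for inhibition of phosphatidylcholine:ceramide cholinephosphotransferase 2 (Homo sapiens), read by HPLC, with stated times of 30 min and 2 h; on this read-out lower numbers stand for stronger inhibition and higher numbers for weaker inhibition:
compound 1 `O=C(Nc1cccnc1)c1ccccc1OCc1ccccc1F` gives 3500 nM
compound 2 `O=C(Nc1cccnc1)c1ccccc1OCc1cccc(F)c1` gives 1600 nM
compound 3 `O=C(Nc1cccnc1)c1ccccc1OCc1cc(Cl)ccc1Cl` gives 990 nM

Compound 3 stands lowest of the three numbers in this assay. One of its gaps is a 3.5-fold lower number from compound 1 to compound 3 (0.55 log units; beyond the scatter), beyond the scatter, while the other, a 1.6-fold lower number from compound 2 to compound 3 (0.21 log units; within the scatter), lies within the scatter, so compound 2 and compound 3 cannot be ordered against each other. The step of a 2.2-fold lower number from compound 1 to compound 2 (0.34 log units; beyond the scatter) shows that moving the single halogen around the ring alters the number modestly.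

Compound 4 `Cc1c(Cl)cccc1COc1ccccc1C(=O)Nc1cccnc1` differs from compound 3 only in the aryl group: 3-chloro-2-methylphenyl in place of 2,5-dichlorophenyl on a saturated chain carbon bound to an oxygen on an aromatic ring. For the measured compounds named here, no measured pair isolates a methyl against a chlorine here; the steps 1>3 and 2>3 only show that swapping one halogen-bearing ring for another moves the number by a modest amount at most. The change into compound 4 keeps a chlorine on the ring and exchanges the other for a methyl, so the step in this assay is expected to stay within the scatter, with a slight lean toward a higher number.

Estimated step: a 1.3-fold higher number from compound 3 to compound 4 (0.12 log units; within the scatter). Compound 4 is expected at 1300 nM, within 500 nM to 3500 nM.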

Compound 4, half-maximal inhibitory concentration: 3800 nM
Compound 4: middle estimate off by 2.9-fold (0.47 log units), on the low side; measured number above the stated range.
By their numbers in this assay, from the lowest: compounds 3 and 2 (each within the scatter of the next); then compounds 1 and 4 (each within the scatter of the next).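

In this assay, keeping a chlorine on the ring does not hold the number near that of compound 3: with 3-chloro-2-methylphenyl in place of 2,5-dichlorophenyl on the saturated chain carbon bound to an oxygen on an aromatic ring, the data show a 3.8-fold higher number from compound 3 to compound 4 (0.58 log units; beyond the scatter), so this aryl group remains sensitive even when its heavy-atom count is unchanged. Against the fluorinated aryl groups the picture is split, with a 2.4-fold higher number from compound 2 to compound 4 (0.38 log units; beyond the scatter) lying beyond the scatter and a 1.1-fold higher number from compound 1 to compound 4 (0.04 log units; within the scatter) lying within it, so 3-chloro-2-methylphenyl and 2-fluorophenyl cannot be ordered against each other at this place. No measurement among the data available here accounts for these steps.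

The step into compound 4 changes both the second substituent and the place of the chlorine, and no pair shown separates the methyl from the relocated chlorine. As far as these compounds go, how an aryl group carrying an amine or a carboxylic acid would read, or how a longer chain at this place would read, stays open.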